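This account rests on a few compounds, and the source may have more. Where it says the series, first, only, none or still open, it means among the compounds named here.

Measured in a physicochemical assay for solubility; on this read-out higher numbers stand for higher solubility and lower numbers for lower solubility:
compound 1 `O=C(c1ccc(C(F)(F)F)cc1)N1CCC(NS(=O)(=O)c2cc(S(=O)(=O)c3ccccc3)ccc2C(F)(F)F)CC1`: 6300 nM
compound 2 `CN(C)c1ccc(C(=O)N2CCC(NS(=O)(=O)c3cc(S(=O)(=O)c4ccccc4)ccc3C(F)(F)F)CC2)cn1`: 12500 nM
compound 3 `O=S(=O)(NC1CCN(S(=O)(=O)c2ccccc2)CC1)c1cc(S(=O)(=O)c2ccccc2)ccc1C(F)(F)F`: 25000 nM

Compound 3 and compound 2 sit together at the upper end of these numbers (a 2.0-fold higher number from compound 2 to compound 3 (0.30 log units; within the scatter)), while compound 1 stands apart from compound 3 (a 4.0-fold higher number from compound 1 to compound 3 (0.60 log units; beyond the scatter)). The remaining step (a 2.0-fold higher number from compound 1 to compound 2 (0.30 log units; within the scatter)) also lies within the scatter.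

Still unmeasured is compound 4 `O=C(O)c1cccc(S(=O)(=O)N2CCC(NS(=O)(=O)c3cc(S(=O)(=O)c4ccccc4)ccc3C(F)(F)F)CC2)c1`, which keeps the sulfonyl link of compound 3 on the ring amine nitrogen and carries carboxy in place of hydrogen on an aromatic carbon. Phenylsulfonyl thus becomes (3-carboxyphenyl)sulfonyl.

For the measured compounds named here, no measured step introduces a carboxy, so the data give no direct precedent. All three steps change the group on the ring amine nitrogen, and they serve only as a guide to size. The only one beyond the scatter is modest (a 4.0-fold higher number from compound 1 to compound 3 (0.60 log units; beyond the scatter)). A step of similar modest size is therefore expected in this assay, with the upward direction a judgement from the structural change alone. The expected step is (a 2.0-fold higher number from compound 3 to compound 4 (0.30 log units; within the scatter)), and it could still fall within the scatter. Compound 4 is estimated at 50000 nM (expected range 20000 nM to 120000 nM).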

Compound 4, solubility: 12500 nM
Estimate against measurement, compound 4: 4.0-fold (0.60 log units) above, and the stated range ends above it.
By their numbers in this assay, from the lowest: compounds 1, 2, 4 and 3 (each within the scatter of the next, the first and the last beyond it).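

In this assay, for the compounds shown here, carboxy on an aromatic carbon of the phenylsulfonyl group is the first carboxy, and its step stays within the scatter (a 2.0-fold lower number from compound 3 to compound 4 (0.30 log units; within the scatter)), so on this read-out compound 4 cannot be told apart from compound 3. Compound 4 also cannot be told apart from the two carbonyl-linked compounds (no change at the digits printed from compound 2 to compound 4 (within the scatter); a 2.0-fold higher number from compound 1 to compound 4 (0.30 log units; within the scatter)), whereas the phenylsulfonyl group of compound 3 does stand clear of the (4-(trifluoromethyl)phenyl)carbonyl group of compound 1 (a 4.0-fold higher number from compound 1 to compound 3 (0.60 log units; beyond the scatter)), and that separation is not seen once carboxy is present. No measurement on hand offers an explanation for this result.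

Still open, on these data alone, is whether an amine, a methyl ester or a tetrazole on this same aromatic carbon would also stay within the scatter of compound 3, and whether carboxy on another carbon of the ring would read the same. Also open, as far as these compounds go, is how carboxy would read on the aryl groups of compound 1 and compound 2, where the link to the ring amine nitrogen is a carbonyl and not a sulfonyl.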